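Acetamido in place of ethoxy: compound 3 to compound 4

A few compounds are considered here, and "the series" means these few. Any claim that something is new, unique, unknown or untested is made for them only; others in the source may bear on it.

In an ADME assay on Vero cells (Chlorocebus sabaeus) for cytotoxicity, read by MTT assay, with a stated time of 72 h (a higher number here means that more compound is tolerated, a lower number that less compound is tolerated), compound 1 `COC(=O)CN1CCN(c2c(F)cc3c(=O)c(C(=O)O)cn(C4CC4)c3c2OC)CC1C` gives 500 ug/mL, compound 2 `CO/N=C(\C)CN1CCN(c2c(F)cc3c(=O)c(C(=O)O)cn(C4CC4)c3c2OC)CC1C` gives 49.6 ug/mL and compound 3 `CCO/N=C(\C)CN1CCN(c2c(F)cc3c(=O)c(C(=O)O)cn(C4CC4)c3c2OC)CC1C` gives 31.3 ug/mL. Compound 3 thus stands at the low end of this small set, level with compound 2. The gap between these two is a 1.6-fold lower number from compound 2 to compound 3 (0.20 log units; within the scatter), which does not separate them. Two steps do lie beyond the scatter: a 10-fold lower number from compound 1 to compound 2 (1.00 log units; beyond the scatter) and a 16-fold lower number from compound 1 to compound 3 (1.20 log units; beyond the scatter).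

Compound 4 `COc1c(N2CCN(C/C(C)=N/NC(C)=O)C(C)C2)c(F)cc2c(=O)c(C(=O)O)cn(C3CC3)c12` differs from compound 3 by one change, acetamido in place of ethoxy on a double-bonded nitrogen. For the measured compounds named here, no measured step makes this exchange. The closest one is methyl in place of hydrogen on a saturated chain carbon bound to an oxygen on an unsaturated carbon, the step already given between compound 2 and compound 3, and it stayed within the scatter. The two steps from compound 1 exchange a whole group on a saturated chain carbon bound to an amine nitrogen in a ring, so they show only that large moves occur in this series. No change beyond the scatter is therefore expected in this assay, though the range is kept wide. The expected step is a 1.4-fold higher number from compound 3 to compound 4 (0.16 log units; within the scatter). For compound 4 the estimate is 45 ug/mL, with an expected range of 16 ug/mL to 150 ug/mL.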

Compound 4, half-maximal cytotoxic concentration: 707 ug/mL
Compound 4: the middle estimate sits 16-fold (1.20 log units) below what was measured; the whole stated range lies below it.
By their numbers in this assay, from the lowest: compounds 3 and 2 (each within the scatter of the next); then compounds 1 and 4 (each within the scatter of the next).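

In this assay, the group on the double-bonded nitrogen proves able to move the number far more than the methoxy and ethoxy pair suggested: acetamido in place of ethoxy gives a 23-fold higher number from compound 3 to compound 4 (1.35 log units; beyond the scatter), and acetamido in place of methoxy gives a 14-fold higher number from compound 2 to compound 4 (1.15 log units; beyond the scatter). The side chain of compound 4 is also the largest group counted in this set, yet it gives a 1.4-fold higher number from compound 1 to compound 4 (0.15 log units; within the scatter), so the low numbers of compound 2 and compound 3 do not follow from group size alone among these four compounds. The exchange adds one hydrogen-bond donor to the count, but nothing measured here accounts for the shift.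

As far as these compounds go, it remains open whether the shift belongs to acetamido alone or extends to other groups at this place, such as a free amine, propionamido or a longer alkoxy chain like propoxy. Also open, from the compounds shown here alone, is whether the amide hydrogen matters, a question that an acetamido carrying methyl in place of that hydrogen would address.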